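Methyl to cyano: a small change and its expected effect

The compounds below may be only part of what the source reports. "The series", "measured", "known", "first", "only" and "open" are said of these compounds alone.

Three compounds have been measured in a functional assay for agonist activity at Free fatty acid receptor 1 (Homo sapiens); on this read-out higher numbers stand for an effect only at larger amounts of compound and lower numbers for an effect already at smaller amounts:
compound 1 `O=C(O)CCc1ccc(NCc2ccc(Cl)cc2)cc1` gives 1000 nM
compound 2 `O=C(O)CCc1ccc(NCc2ccc(C(F)(F)F)cc2)cc1` gives 2000 nM
compound 3 `Cc1ccc(CNc2ccc(CCC(=O)O)cc2)cc1` gives 3980 nM

Compound 3 stands at the highest number of the three, so it needs the largest amount of compound to produce its effect. Its distance from compound 2 lies within the scatter, whereas the step of a 4.0-fold higher number from compound 1 to compound 3 (0.60 log units; beyond the scatter) lies beyond it, so only compound 1 is clearly separated from compound 3.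

Compound 4 `N#Cc1ccc(CNc2ccc(CCC(=O)O)cc2)cc1` differs from compound 3 in a single place: cyano in place of methyl on an aromatic carbon. All three measured compounds vary at exactly this place, so the steps of a 4.0-fold higher number from compound 1 to compound 3 (0.60 log units; beyond the scatter) and a 2.0-fold higher number from compound 2 to compound 3 (0.30 log units; within the scatter) bear directly on the change. Read in the reverse direction, both show that exchanging the methyl for another group gave a lower number, once modestly and once within the scatter. Cyano itself has not been tested, so its direction cannot be read from the data. The expectation for this assay is therefore a step of uncertain direction, probably no larger than modest, leaning slightly toward a lower number. Compound 4 is expected at 2500 nM, within 800 nM to 8000 nM, which corresponds to an expected step of a 1.6-fold lower number from compound 3 to compound 4 (0.20 log units; within the scatter).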

Compound 4, half-maximal effective concentration: < 31700 nM
Compound 4: only a limit was reported; the forecaster's own chance of this, stated with the estimate: 5%; the middle value does not contradict the limit.
By their numbers in this assay, from the lowest: compounds 1, 2 and 3 (each within the scatter of the next, the first and the last beyond it).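

In this assay compound 4 is reported only as a limit, < 31700 nM, and not as a number. With this limit, the steps from compound 1, compound 2 and compound 3 to compound 4 cannot be read. The compounds shown leave open whether cyano in place of methyl gives a higher or a lower number, and by how much.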